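Exchanging the aryl group on a ring nitrogen: cytotoxicity

The source may hold more compounds than are shown below. What is called first, only, known or untested is meant among the compounds shown, and "the series" means these compounds.

Measured so far:
compound 1, `CC(C)c1ccc(-n2nc(-c3ccc(C(F)(F)F)cc3O)nc2-c2ccccc2O)cc1`, 108%
compound 2, `CC(C)(C)c1ccc(-n2nc(-c3ccc(C(F)(F)F)cc3O)nc2-c2ccccc2O)cc1`, 81.1%

In a functional assay on PC-12 cells (Rattus norvegicus) for cytotoxicity, read by MTT assay, with stated times of 2 h and 24 h, tested at 10 uM (on this read-out higher numbers stand for a stronger effect at the one concentration tested and lower numbers for a weaker effect), compound 1 gives 108% and compound 2 gives 81.1%. Going by the values given here, compound 2 stands lowest of the two numbers, set apart by the only measured step, a number 26.9 percentage points lower from compound 1 to compound 2 (beyond the scatter). Compound 3, `Oc1cc(C(F)(F)F)ccc1-c1nc(-c2ccccc2O)n(-c2ccc(Cl)cc2Cl)n1`, differs from compound 2 by 2,4-dichlorophenyl in place of 4-(tert-butyl)phenyl on an aromatic nitrogen. Among the compounds with values here, the measured step changed only a methyl within the group that now leaves; no step exchanges the whole group, so the data give little guidance. Compound 3 is expected to stay near compound 2, the estimated step being a number 8.9 percentage points higher from compound 2 to compound 3 (within the scatter). The estimate for compound 3 is 90%, ranging from 55% to 125%.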

Compound 3, a percentage reported as activity, at one concentration (the size of the read-out at that concentration, not a potency): 95.2%
Beside the measured number, compound 3's estimate is 5.2 percentage points below it, within the range that was stated.
By their numbers in this assay, from the lowest: compound 2; then compound 3; then compound 1.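

In this assay the exchange of the whole group on the aromatic nitrogen for 2,4-dichlorophenyl gives a number 14.1 percentage points higher from compound 2 to compound 3 (beyond the scatter) and also a number 12.8 percentage points lower from compound 1 to compound 3 (beyond the scatter) on the other side. This position therefore accepts a chlorine-bearing phenyl in place of an alkyl-bearing one, and the number falls between those of the two alkyl-bearing compounds. No measurement offered here explains these differences. The compounds shown leave open whether a single chlorine would give the same number, and how a phenyl carrying an amine or a carboxylic acid would read at this position.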